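Replacing the benzamide of compound 1 with a benzylamine

The source may hold more compounds than are shown below. What is called first, only, known or untested is meant among the compounds shown, and "the series" means these compounds.

Compound 1 `CC(C)c1onc(-c2c(Cl)cccc2Cl)c1COc1ccc(N(C)C(=O)c2ccc(C(=O)O)cc2)c(C(F)(F)F)n1`: 316 nM
Compound 2 `Cc1nc(OCc2c(-c3c(Cl)cccc3Cl)noc2C(C)C)ccc1N(C)C(=O)c1ccc(C(=O)O)cc1`: 2030 nM

For the measured compounds named here, in a functional assay on HEK293 cells for agonist activity at Bile acid receptor (Homo sapiens) (a lower number here means that less compound is needed, a higher number that more compound is needed for the effect), compound 1 gives 316 nM, the lowest of the two numbers; the only other measured compound, compound 2, gives 2030 nM, and the step of a 6.4-fold higher number from compound 1 to compound 2 (0.81 log units; beyond the scatter) is the sole measured step available. Compound 3 `CC(C)c1onc(-c2c(Cl)cccc2Cl)c1COc1ccc(N(C)Cc2ccc(OCC(=O)O)cc2)c(C(F)(F)F)n1` has not yet been measured. It differs from compound 1 by 4-(carboxymethoxy)benzyl in place of (4-carboxyphenyl)carbonyl on a nitrogen on an aromatic ring. Going by the values given here, the measured step from compound 1 to compound 2 concerns a methyl-for-trifluoromethyl exchange elsewhere in the shared core and says nothing about the exchange made here; no measured pair addresses the change of the linker group on the ring nitrogen. The expectation for compound 3 therefore rests on compound 1 alone and is wide. A step of a 2.2-fold higher number from compound 1 to compound 3 (0.35 log units; beyond the scatter) is expected. Compound 3 is estimated at 700 nM, within a range from 120 nM to 4000 nM.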

Compound 3, half-maximal effective concentration: 214 nM
Compound 3: the middle estimate sits 3.3-fold (0.51 log units) above what was measured; measured number inside the range.
By their numbers in this assay, from the lowest: compounds 3 and 1 (each within the scatter of the next); then compound 2.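

The nitrogen on the aromatic ring carries either (4-carboxyphenyl)carbonyl or 4-(carboxymethoxy)benzyl in this assay with no difference beyond the scatter (a 1.5-fold lower number from compound 1 to compound 3 (0.17 log units; within the scatter)). Two things change together in this exchange, the carbonyl giving way to a benzyl carbon and the carboxylic acid coming to stand on a carboxymethoxy chain, and the number still holds, which the earlier step, concerned with trifluoromethyl and methyl, could not show for this nitrogen. Nothing available explains why the two groups read alike.

The compounds shown leave open what each of these two alterations does alone, since they appear only together here. Also open, from the compounds shown here alone, are whether a longer chain carrying the carboxylic acid, or a tetrazole in place of that acid, would keep the number, and whether methyl in place of trifluoromethyl costs as much with 4-(carboxymethoxy)benzyl on the nitrogen.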